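A 4-Methylphenyl Exchange on an Aromatic Carbon

The source may hold more compounds than are shown below. What is called first, only, known or untested is meant among the compounds shown, and "the series" means these compounds.

In a functional assay on CCRF-CEM cells (Homo sapiens) for antiproliferative activity (a higher number here means a weaker inhibitor, a lower number a stronger inhibitor), compound 2 `COc1cccc(-c2cc(N)c(C(=O)c3cc(OC)c(OC)c(OC)c3)s2)c1` gives 16 nM, level with compound 1 `COc1cc(C(=O)c2sc(-c3ccccc3Cl)cc2N)cc(OC)c1OC` at 16 nM. Compound 3 `COc1cc(C(=O)c2sc(-c3ccc(C)cc3)cc2N)cc(OC)c1OC` carries 4-methylphenyl in place of 3-methoxyphenyl on an aromatic carbon next to the ring sulfur (4-methylphenyl in place of 3-methoxyphenyl on an aromatic carbon). Among the measured compounds shown here, the one measured step at this carbon is no change at the digits printed from compound 1 to compound 2 (within the scatter), made by 3-methoxyphenyl in place of 2-chlorophenyl. With that single step as the guide, no step beyond the scatter is expected in this assay, in either direction. The expected step is no change at the digits printed from compound 2 to compound 3 (within the scatter). For compound 3 the estimate is 16 nM, with an expected range of 6 nM to 45 nM.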

Compound 3, half-maximal inhibitory concentration: 15 nM
Estimate against measurement, compound 3: 1.1-fold (0.03 log units) above; the range from low to high includes it.
By their numbers in this assay, from the lowest: compounds 3, 1 and 2 (each within the scatter of the next).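

In this assay, 4-methylphenyl in place of 3-methoxyphenyl gives a 1.1-fold lower number from compound 2 to compound 3 (0.03 log units; within the scatter), and 4-methylphenyl in place of 2-chlorophenyl gives a 1.1-fold lower number from compound 1 to compound 3 (0.03 log units; within the scatter). The aromatic carbon next to the ring sulfur thus carries a third substituted phenyl, now one with only carbon atoms and no hydrogen-bond acceptor, and all three compounds stay within the scatter of one another. Nothing available accounts for this flat result.

All three groups at this carbon are substituted phenyls. On these data alone, whether a phenyl bearing an amine or a carboxylic acid, or a longer chain in place of the methyl, would keep these values remains open.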